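From pyridin-4-yl to cyclopentyl on the amide carbonyl

The source may hold more compounds than are shown below. What is called first, only, known or untested is meant among the compounds shown, and "the series" means these compounds.

Compound 3 `O=C(Nc1cc(-c2ccccc2)nn1-c1ccccc1)c1ccncc1` carries pyridin-4-yl on a carbonyl carbon. In an assay on HEK293 cells for displacement of a labelled ligand from metabotropic glutamate receptor 5 (Rattus norvegicus) (on this read-out lower numbers stand for stronger inhibition and higher numbers for weaker inhibition), compound 3 gives > 10000 nM, which is a limit of the assay rather than a number. Compound 1 `COc1cccc(C(=O)Nc2cc(-c3ccccc3)nn2-c2ccccc2)c1`, with 3-methoxyphenyl in that position, gives 1290 nM in this assay. Compound 2 `NC(=O)c1ccc(C(=O)Nc2cc(-c3ccccc3)nn2-c2ccccc2)cc1` gives > 10000 nM in this assay, again a limit. The steps of an at least 7.7-fold higher number from compound 1 to compound 2 (0.88 log units; beyond the scatter) and an at least 7.7-fold higher number from compound 1 to compound 3 (0.88 log units; beyond the scatter) show both replacements losing affinity, while a step that the two limits leave unreadable from compound 2 to compound 3 stays unreadable because the limit of > 10000 nM in this assay, at which 2 of the 3 values shown sit, sits at both of its ends.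

Compound 4 `O=C(Nc1cc(-c2ccccc2)nn1-c1ccccc1)C1CCCC1` differs from compound 3 by cyclopentyl in place of pyridin-4-yl on a carbonyl carbon. Among the measured compounds shown here, no measured step touches cyclopentyl, and compound 3 offers only a limit, so the step of an at least 1.6-fold lower number from compound 3 to compound 4 (0.22 log units; that floor lies within the scatter) is expected only loosely. Compound 4 is estimated at 6000 nM, within 1000 nM to 30000 nM, with a real chance that this assay again reports only a limit.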

Compound 4, inhibition constant: 11600 nM
Compound 4: the middle estimate sits 1.9-fold (0.29 log units) below what was measured; low and high end bracket the measured number.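

Cyclopentyl, a non-aromatic ring of carbon only, gives a measured number in this assay, but it does not match 3-methoxyphenyl: a 9.0-fold higher number from compound 1 to compound 4 (0.95 log units; beyond the scatter). On this carbonyl carbon, all three replacements shown lose affinity compared with compound 1, whether the incoming ring is aromatic or not. The steps from compound 2 and compound 3 to compound 4 cannot be read because a limit stands at one end of each: the limit of > 10000 nM in this assay, at which 2 of the 4 values shown sit.

Still open, going by these compounds, is whether an open butyl chain on this carbonyl carbon would come closer to compound 1. Also open, on these data alone, is whether plain phenyl, without the methoxy group, would keep the affinity of compound 1.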